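Shifting the methoxy group on the benzyl ether

This account rests on a few compounds, and the source may have more. Where it says the series, first, only, none or still open, it means among the compounds named here.

The series is built on one shared core carrying a substituted benzyl ether. Compound 1 `COc1cccc(OC)c1OCCNCCOc1ccccc1OCc1ccc(C)cc1` bears a 4-methylphenyl group there, and in an assay on CHO cells for displacement of a labelled ligand from Alpha-1A adrenergic receptor (Homo sapiens) (a lower number here means a stronger inhibitor, a higher number a weaker inhibitor), compound 1 gives 2 nM. Compound 2 `COc1cccc(COc2ccccc2OCCNCCOc2c(OC)cccc2OC)c1` replaces that group with 3-methoxyphenyl, and in this assay compound 2 gives 2 nM. The step of no change at the digits printed from compound 1 to compound 2 (within the scatter) shows that this exchange left the inhibition constant unchanged within the scatter, so compound 2 stands level with compound 1.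

Compound 3 `COc1ccc(COc2ccccc2OCCNCCOc2c(OC)cccc2OC)cc1` differs from compound 2 by 4-methoxyphenyl in place of 3-methoxyphenyl on a saturated chain carbon bound to an oxygen on an aromatic ring. Going by the values given here, the only measured step that bears on this position, no change at the digits printed from compound 1 to compound 2 (within the scatter), was flat, and both known compounds sit at the same level, so no movement beyond the scatter is anticipated for this further rearrangement of the same atoms. The expected step of a 1.5-fold higher number from compound 2 to compound 3 (0.18 log units; within the scatter) is accordingly estimated to lie within the scatter. Compound 3 is therefore expected to give about 3 nM in this assay, with a range from 1 nM to 9 nM.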

Compound 3, inhibition constant: 2 nM
Beside the measured number, compound 3's estimate is 1.5-fold (0.18 log units) above it, within the range that was stated.
By their numbers in this assay, from the lowest: compounds 1, 2 and 3 (each within the scatter of the next).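

Moving the methoxy group within the same atoms, from 3-methoxyphenyl to 4-methoxyphenyl on a saturated chain carbon bound to an oxygen on an aromatic ring, gives no change at the digits printed from compound 2 to compound 3 (within the scatter) in this assay and so does not separate these two placings of the group. The pair of compounds 1 and 3 adds a cleaner comparison than the earlier pair, since only methoxy in place of methyl on an aromatic carbon differs between them, and it gives no change at the digits printed from compound 1 to compound 3 (within the scatter) in the same read-out of this assay with the group's place held fixed. Nothing available accounts for why these exchanges leave the number level.

Going by these compounds, the three compounds carry only small methyl and methoxy groups on this ring, so it remains open whether the same level would hold with an amine or a carboxylic acid there, or with a longer chain such as ethoxy or butoxy. On these data alone, it is also open whether the level depends on having any group on the ring at all, as a plain phenyl group would show.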